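The source may report more compounds than this note shows. Statements on the series, on what has been measured and on what is new or still open speak of the compounds shown alone.

Values in a functional assay on Huh-7 cells (Homo sapiens) for cytotoxicity, read by MTT assay, with a stated time of 3 days (a higher number here means that more compound is tolerated, a lower number that less compound is tolerated), so far:
- compound 1 `OC[C@H]1O[C@@H](n2cnc3c(Cn4ccc5ccccc54)ncnc32)[C@H](O)[C@@H]1O` gives > 250000 nM (a limit of the assay)
- compound 2 `CN(Cc1ccccc1)Cc1ncnc2c1ncn2[C@@H]1O[C@H](CO)[C@@H](O)[C@H]1O` gives 9000 nM

Among the compounds with values here, compound 2 holds the only true number in this assay so far. Compound 3 `OC[C@H]1O[C@@H](n2cnc3c(CSc4ccccc4)ncnc32)[C@H](O)[C@@H]1O` differs from it by one change: phenylsulfanyl in place of benzyl(methyl)amino on a saturated chain carbon bound to an aromatic carbon on the same chain carbon. Within the data shown here, this removes the benzyl(methyl)amino group that marks the only measured step, a large one beyond the scatter (an at least 27-fold lower number from compound 1 to compound 2 (1.44 log units; beyond the scatter)). One step gives thin support, but a higher number is expected, smaller than that step or similar in size. The estimated change in this assay is a 4.4-fold higher number from compound 2 to compound 3 (0.65 log units; beyond the scatter) and it remains uncertain. For compound 3 the estimate is 40000 nM (range 8000 nM to 200000 nM).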

Compound 3, half-maximal cytotoxic concentration: > 100000 nM
Compound 3: a limit, no number (the forecaster's own chance of this, stated with the estimate: 30%); at least 2.5-fold (0.39 log units) between middle value and limit.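

In this assay, phenylsulfanyl on the saturated chain carbon bound to an aromatic carbon behaves like 1H-indol-1-yl, so the low number of compound 2 now stands against two replacements rather than one, with an at least 11-fold higher number from compound 2 to compound 3 (1.04 log units; beyond the scatter). Compound 3 gives a limit, not a number: the limit of > 100000 nM in this assay, at which 1 of the 3 values shown sits. The step from compound 1 to compound 3 cannot be read, since both values are limits.

On these data alone, whether the lower number of compound 2 goes with the amine nitrogen or with the benzyl group stays open. A dimethylamino or a benzyloxy group on the same chain carbon would separate the two.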